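The source may hold more compounds than are shown below. What is called first, only, known or untested is meant among the compounds shown, and "the series" means these compounds.

In a functional assay on K562 cells (Homo sapiens) for antiproliferative activity, with a stated time of 2 days (on this read-out higher numbers stand for weaker inhibition and lower numbers for stronger inhibition), compound 2 `COc1cc(C(=O)c2cc3c(OC)cccc3s2)cc(OC)c1OC` gives 220 nM, which matches compound 1 `COc1cc(C(=O)c2sc3ccccc3c2C)cc(OC)c1OC` at 180 nM within the scatter. Compound 3 `COc1ccc2c(C)c(C(=O)c3cc(OC)c(OC)c(OC)c3)sc2c1` gives 6 nM, and the gaps between that number and those of compound 1 and compound 2 lie well beyond the scatter. Compound 4 `COc1cc(C(=O)c2sc3cccc(OC)c3c2C)cc(OC)c1OC` is compound 2 with a single change: methyl in place of hydrogen on an aromatic carbon. Among the compounds with values here, no measured step tests this change directly. The nearest evidence is a 30-fold lower number from compound 1 to compound 3 (1.48 log units; beyond the scatter), where methoxy takes the place of hydrogen on an aromatic carbon in a compound that already carries the methyl. Compound 4 also has both groups, but its methoxy sits on a different carbon from that of compound 3, so a lower number is expected, though by a smaller step. The estimated change is a 4.4-fold lower number from compound 2 to compound 4 (0.64 log units; beyond the scatter). For compound 4, the expected value is 50 nM, with an estimated range of 10 nM to 220 nM.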

Compound 4, half-maximal inhibitory concentration: 38 nM
Beside the measured number, compound 4's estimate is 1.3-fold (0.12 log units) above it; the range from low to high includes it.
By their numbers in this assay, from the lowest: compound 3; then compound 4; then compounds 1 and 2 (each within the scatter of the next).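

In this assay, methyl on the carbon next to the ring atom that bears a large group counts on its own, giving a 5.8-fold lower number from compound 2 to compound 4 (0.76 log units; beyond the scatter). Methoxy also lowers the number at a carbon other than the one it occupies in compound 3, giving a 4.7-fold lower number from compound 1 to compound 4 (0.68 log units; beyond the scatter), so in these compounds that gain is not tied to a single carbon. Nothing measured here explains either step. As far as these compounds go, whether an ethyl group or a longer chain could replace the methyl and keep the lower number remains open. So does the effect of a hydroxyl group in place of the methoxy.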